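This account rests on a few compounds, and the source may have more. Where it says the series, first, only, none or still open, it means among the compounds named here.

Compound 1 `NC1CCc2nc(-c3ccncc3)nc(Nc3ccc(F)cc3)c2C1`: 22900 nM
Compound 2 `NC1CCc2nc(-c3ccncc3)nc(Nc3cccc(F)c3)c2C1`: 19400 nM
Compound 3 `N[C@@H]1CCc2nc(-c3ccncc3)nc(Nc3cccc(F)c3)c2C1`: 17800 nM

In a functional assay on A549 cells (Homo sapiens) for antiproliferative activity, read by MTT assay, with a stated time of 72 h (on this read-out higher numbers stand for weaker inhibition and lower numbers for stronger inhibition), compound 2 gives 19400 nM, within the scatter of both other compounds. Compound 4 `CN(C)c1ccc(Nc2nc(-c3ccncc3)nc3c2CC(N)CC3)cc1` is still unmeasured. It differs from compound 2 as follows: 4-(dimethylamino)phenyl in place of 3-fluorophenyl on a nitrogen on an aromatic ring. That is, 4-(dimethylamino)phenyl in place of 3-fluorophenyl on a nitrogen on an aromatic ring. The nearest evidence is a 1.2-fold lower number from compound 1 to compound 2 (0.07 log units; within the scatter), a fluorine-bearing group exchanged for another at the same place. For the measured compounds named here, it offers only a weak guide, since no measured compound carries the entering group. The other step, a 1.1-fold lower number from compound 2 to compound 3 (0.04 log units; within the scatter), concerns only the fact that one of compounds 2 and 3 is drawn with a defined configuration and the other without, at the place where they differ and has no bearing on this change. No step beyond the scatter is therefore expected, and the estimated change is a 1.2-fold lower number from compound 2 to compound 4 (0.08 log units; within the scatter). For compound 4 the expected value is 16000 nM, with an estimated range of 5000 nM to 40000 nM.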

Compound 4, half-maximal inhibitory concentration: 17100 nM
The estimate for compound 4 lay 1.1-fold (0.03 log units) below the measured number; measured number inside the range.
By their numbers in this assay, from the lowest: compounds 4, 3, 2 and 1 (each within the scatter of the next).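

In this assay, 4-(dimethylamino)phenyl in place of 3-fluorophenyl gives a 1.1-fold lower number from compound 2 to compound 4 (0.05 log units; within the scatter), and dimethylamino in place of fluoro on an aromatic carbon gives a 1.3-fold lower number from compound 1 to compound 4 (0.13 log units; within the scatter). The place on the nitrogen thus accepts a group with a nitrogen and a hydrogen-bond acceptor, not only a fluorine-bearing phenyl, with no step beyond the scatter. Nothing available bears on why this exchange leaves the number within the scatter. Still open, going by these compounds, is whether a carboxylic acid or a longer alkyl chain on this phenyl would give a step beyond the scatter.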